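A few compounds are considered here, and "the series" means these few. Any claim that something is new, unique, unknown or untested is made for them only; others in the source may bear on it.

Measured compounds and their numbers:
compound 1, `Nc1nc(-c2ccc(Cl)o2)nc2sc(CN3CCCC3)cc12`, 710 nM
compound 2, `Nc1nc(-c2ccc(Cl)o2)nc2sc(CN3CCC(F)CC3)cc12`, 1080 nM
compound 3, `Nc1nc(-c2ccc(Cl)o2)nc2sc(CN3CC=CCC3)cc12`, 190 nM

These three share one core and differ only in the ring-bearing amine attached to a saturated chain carbon. In an assay on CHO-K1 cells for antagonist activity at adenosine receptor A1 (Homo sapiens), read by a beta-galactosidase reporter, with stated times of 15 min and 6 h (on this read-out lower numbers stand for stronger inhibition and higher numbers for weaker inhibition), compound 3 gives the lowest number of the three: a 3.7-fold lower number from compound 1 to compound 3 (0.57 log units; beyond the scatter) and a 5.7-fold lower number from compound 2 to compound 3 (0.75 log units; beyond the scatter), both beyond the scatter, while a 1.5-fold higher number from compound 1 to compound 2 (0.18 log units; within the scatter) stays within it.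

Compound 4, `N#Cc1cccc(-c2nc(N)c3cc(CN4CC=CCC4)sc3n2)c1`, keeps the amine ring of compound 3 and changes a different part: 3-cyanophenyl in place of 5-chlorofuran-2-yl on an aromatic carbon of the shared core. Among the compounds with values here, none of the measured steps touches this position; all three vary only the amine ring. The measured data therefore give no direct guide to the size or direction of this change, and the expectation must be wide.

Compound 4 is estimated at 400 nM, with a range from 80 nM to 2000 nM, which means an expected step of a 2.1-fold higher number from compound 3 to compound 4 (0.32 log units; beyond the scatter) in this assay.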

Compound 4, inhibition constant: 210 nM
The estimate for compound 4 lay 1.9-fold (0.28 log units) above the measured number; low and high end bracket the measured number.
By their numbers in this assay, from the lowest: compounds 3 and 4 (each within the scatter of the next); then compounds 1 and 2 (each within the scatter of the next).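

In this assay, putting 3-cyanophenyl in place of 5-chlorofuran-2-yl on the aromatic carbon between two ring nitrogen atoms gives a 1.1-fold higher number from compound 3 to compound 4 (0.04 log units; within the scatter), so the two compounds cannot be told apart. Within the data shown here, this is the first view of this position, which until now had held only the chlorofuran. With this amine ring, the position takes a six-membered carbon ring carrying a nitrile in place of the five-membered ring carrying chlorine, with no measurable difference in the number. Nothing available explains why the two groups read alike.

From the compounds shown here alone, the 3-cyanophenyl group appears here only with the amine ring of compound 3, so its behaviour with the pyrrolidin-1-yl or 4-fluoropiperidin-1-yl amines remains open. Also open, going by these compounds, is how a plain phenyl or an unsubstituted furan-2-yl would read at this position, which would show what the nitrile and the chlorine each contribute.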